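The source may report more compounds than this note shows. Statements on the series, on what has been measured and on what is new or still open speak of the compounds shown alone.

Of the compounds shown here, two sharing one core have been measured in a functional assay on the whole organism (strain NMRI) with Mus musculus as the target, with a stated time of 60 min, at a dose of 10 mg/kg by the intraperitoneal route; on this read-out higher numbers stand for a stronger effect at the one dose given and lower numbers for a weaker effect. Compound 1 `CSc1nnc(Cc2ccccc2Oc2ccccc2)[nH]1` gives 133% in this assay. Compound 2 `CCSc1nnc(Cc2ccccc2Oc2ccccc2)[nH]1` gives 142% in this assay. Going by the values given here, the one step between them, methyl in place of hydrogen on a saturated chain carbon bound to a sulfur, is a number 9 percentage points higher from compound 1 to compound 2 (within the scatter), so the two numbers lie within the scatter of each other, and compound 2 cannot be set above compound 1 on these figures; it stands beside it.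

Compound 3 `CCCSc1nnc(Cc2ccccc2Oc2ccccc2)[nH]1` has not yet been measured in this assay. It differs from compound 2 by methyl in place of hydrogen on a saturated chain carbon, two bonds along the chain from a sulfur.

Among the compounds with values here, the only measured step that bears on this change is the one from compound 1 to compound 2, which also lengthened the chain on the sulfur by a methyl and stayed within the scatter. On that basis no step beyond the scatter is expected from compound 2 to compound 3 in this assay, and the estimated step is a number 3 percentage points higher from compound 2 to compound 3 (within the scatter). For compound 3 the value expected in this assay is 145%, with a range from 120% to 170%.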

Compound 3, a percentage reported as activity, at one dose (the size of the read-out at that dose, not a potency): 139%
Beside the measured number, compound 3's estimate is 6 percentage points above it, and the stated range covers the measured number.
By their numbers in this assay, from the lowest: compounds 1, 3 and 2 (each within the scatter of the next).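

With compound 3 the chain on the sulfur has now been extended twice, and the second extension behaves like the first: in this assay, methyl in place of hydrogen on a saturated chain carbon, two bonds along the chain from a sulfur, gives a number 3 percentage points lower from compound 2 to compound 3 (within the scatter), and the two extensions taken together give a number 6 percentage points higher from compound 1 to compound 3 (within the scatter). The earlier single step could not show this, but all three compounds now stand level within the scatter, so across these three there is no trend with chain length, and propylsulfanyl in place of ethylsulfanyl leaves no readable mark on this read-out. Nothing shown gives a reason for this flat picture.

From the compounds shown here alone, it stays open what a longer chain such as butyl, a branched group such as isopropyl, or a chain ending in an amine or a carboxylic acid would do at this sulfur. The read-out also comes from one dose, so these figures do not say whether the three compounds share a potency.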